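The source may report more compounds than this note shows. Statements on the series, on what has been measured and on what is new or still open speak of the compounds shown alone.

In a physicochemical assay for solubility, read by turbidimetry, measured as kinetic solubility, at pH 7.4 (on this read-out higher numbers stand for higher solubility and lower numbers for lower solubility), compound 2 `C#Cc1cccc(N2C(=O)CSC2c2cccc(C(=O)NCCCCc3ccccc3)c2)c1` gives 10000 nM, and compound 1 `Cc1cccc(N2C(=O)CSC2c2cccc(C(=O)NCCCCc3ccccc3)c2)c1` gives 10000 nM, so the two stand level. The next compound to be measured is compound 3 `O=C(NCCCCc1ccccc1)c1cccc(C2SCC(=O)N2c2cccc(F)c2)c1`. It differs from compound 2 at a single place, with fluoro in place of ethynyl on an aromatic carbon. Among the measured compounds shown here, only one measured step bears on this change, the one that put ethynyl in place of methyl on an aromatic carbon: no change at the digits printed from compound 1 to compound 2 (within the scatter). For the measured compounds named here, that is thin evidence, since it is a single step and no compound carrying fluoro has a measured value yet. Still, it offers no reason to expect movement in this assay, so the expected outcome is no change at the digits printed from compound 2 to compound 3 (within the scatter), with nothing beyond the scatter. For compound 3 the estimated value is 10000 nM, with an expected range from 5000 nM to 20000 nM.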

Compound 3, solubility: 10000 nM
Compound 3: middle estimate and measured number agree at the digits printed; measured number inside the range.
By their numbers in this assay, from the lowest: compounds 1, 2 and 3 (each within the scatter of the next).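

In this assay, fluoro in place of ethynyl on this aromatic carbon gives no change at the digits printed from compound 2 to compound 3 (within the scatter) and fluoro in place of methyl gives no change at the digits printed from compound 1 to compound 3 (within the scatter); the earlier pair compared only methyl with ethynyl. This position has now carried three different groups, including a single fluorine atom and a two-carbon group with a triple bond, and all three compounds stand level in this read-out. Nothing available here explains why the read-out stays level across these groups.

From the compounds shown here alone, whether an amine or a carboxylic acid at this same place would move the number remains open. Also open, going by these compounds, is whether a change elsewhere in the molecule, such as a longer chain on the amide, would leave the read-out just as level.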